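The source may report more compounds than this note shows. Statements on the series, on what has been measured and on what is new or still open speak of the compounds shown alone.

Compound 1 `CC(=O)OC(C)n1cnc2c(Cl)nc(N)nc21` gives > 500000 nM in a functional assay on SW-620 cells (Homo sapiens) for inhibition (a higher number here means a weaker inhibitor, a lower number a stronger inhibitor), which is a limit of the assay and not a number.
Compound 2 `CC(O)n1cnc2c(N)nc(I)nc21` gives > 500000 nM, again only a limit.
Compound 3 `Nc1nc(I)nc2c1ncn2OCCO` gives > 500000 nM, also a limit.

Compound 3 therefore stands nowhere that can be placed on a scale: every value shown rests at the limit of > 500000 nM in this assay, at which 3 of the 3 values shown sit. Within the data shown here, the one measured step, a step that the two limits leave unreadable from compound 2 to compound 3, is unreadable for the same reason. Compound 4 `COc1nc(I)nc2c1ncn2OCCO` differs from compound 3 by methoxy in place of amino on an aromatic carbon. Among the measured compounds shown here, no measured step touches this change, and none of the three compounds gives a number that could anchor it. With every neighbour sitting at the same limit, compound 4 is expected to give 500000 nM, in a range from 100000 nM to 2000000 nM. The expected step of a number no higher from compound 3 to compound 4 (the limit leaves the size open) is thus none beyond the scatter, and a limit is again the likeliest report.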

Compound 4, half-maximal inhibitory concentration: > 500000 nM
Compound 4 was reported as a limit; the forecaster's own chance of this, stated with the estimate: 85%; the middle value sits exactly at the limit.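

Compound 3 and compound 4 both rest at a limit of the assay and not at a number, so no step between them can be read: the limit of > 500000 nM in this assay, at which 4 of the 4 values shown sit.

The compounds shown leave open how strongly any of them inhibits in this assay, and whether methoxy or amino on that aromatic carbon makes any difference.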